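This account rests on a few compounds, and the source may have more. Where it says the series, first, only, none or still open, it means among the compounds named here.

Measured compounds:
- compound 1, `Cn1c(-c2ccccc2)nc2c1c(=O)[nH]c(=O)n2C`, in an assay for binding affinity to adenosine receptor A1 (Rattus norvegicus), read by radioligand binding (a higher number here means a weaker inhibitor, a lower number a stronger inhibitor), compound 1 gives 3400 nM
- compound 2, `Cc1nc2c(=O)n(C)c(=O)n(C)c2[nH]1`, in this assay compound 2 gives 8800 nM

Compound 2 stands highest of the two numbers in this assay; the nearest, compound 1, sits at a lower number, and that gap lies beyond the usual scatter. Going by the values given here, compound 1 and compound 2 differ in more than one place, so no single step between them can be read; their two values only show that the larger aromatic substituent on the five-membered ring goes with a lower number here.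

Compound 3, `CCC/C=C/c1nc2c(=O)n(C)c(=O)n(C)c2[nH]1`, is not yet measured. It differs from compound 2 by pent-1-en-1-yl in place of methyl on an aromatic carbon. Among the compounds with values here, no measured pair isolates this kind of change. Based on the two values in hand, with compound 1 at 3400 nM and compound 2 at 8800 nM, the step from compound 2 to compound 3 is expected to go toward a lower number, by a size clearly beyond the scatter, a 22-fold lower number from compound 2 to compound 3 (1.34 log units; beyond the scatter). Compound 3 is therefore estimated at 400 nM, within a range of 80 nM to 2500 nM.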

Compound 3, inhibition constant: 380 nM
Beside the measured number, compound 3's estimate is 1.1-fold (0.02 log units) above it; the range from low to high includes it.
By their numbers in this assay, from the lowest: compound 3; then compound 1; then compound 2.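

In this assay, the aromatic carbon between two ring nitrogen atoms now has a step that can be read at a single place: pent-1-en-1-yl in place of methyl gives a 23-fold lower number from compound 2 to compound 3 (1.36 log units; beyond the scatter), a large change beyond the scatter. This shows that the substituent at this carbon alone can move the number strongly, and that the entering group does so with no ring and with no hydrogen-bond donors or acceptors, something that compound 1 and compound 2 could not show, since they differ in more than one place, as do compound 1 and compound 3, so neither pair gives a readable step. Nothing at hand accounts for the size of this step.

Open, from the compounds shown here alone, is whether the double bond or the chain length carries the step: a saturated pentyl chain at this carbon would separate the two, and a longer chain would show whether the number keeps falling. Also open, going by these compounds, is how a chain ending in an amine or a carboxylic acid would read here, and how a phenyl group on the core of compound 2 would compare with pent-1-en-1-yl.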